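Ring closure of the butyl chain on an aminoquinoline ether

This account rests on a few compounds, and the source may have more. Where it says the series, first, only, none or still open, it means among the compounds named here.

Compound 1 `CC(C)Oc1cccc2ccc(N)nc12`: 437 nM
Compound 2 `Nc1ccc2cccc(OCC3CCCC3)c2n1`: 53 nM
Compound 3 `CCCCCOc1cccc2ccc(N)nc12`: 580 nM

In an assay on cells with melanin-concentrating hormone receptor 1 (Homo sapiens) as the target, read by radioligand binding (on this read-out higher numbers stand for weaker inhibition and lower numbers for stronger inhibition), compound 3 stands highest of the three numbers; compound 1 sits near it, a 1.3-fold higher number from compound 1 to compound 3 (0.12 log units; within the scatter), while compound 2 lies well apart, an 11-fold higher number from compound 2 to compound 3 (1.04 log units; beyond the scatter). Compound 4 `Nc1ccc2cccc(OCC3CCC3)c2n1` differs from compound 3 by cyclobutyl in place of butyl on a saturated chain carbon bound to an oxygen on an aromatic ring. Among the measured compounds shown here, the step that bears on this is the one from compound 2 to compound 3, where cyclopentyl gave way to butyl and the number rose by an 11-fold higher number from compound 2 to compound 3 (1.04 log units; beyond the scatter); the step of an 8.2-fold lower number from compound 1 to compound 2 (0.92 log units; beyond the scatter) points the same way. Closing the chain into cyclobutyl is therefore expected to lower the number, likely by somewhat less than a full return, a 5.3-fold lower number from compound 3 to compound 4 (0.72 log units; beyond the scatter). Compound 4 is estimated at 110 nM, within 40 nM to 300 nM.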

Compound 4, half-maximal inhibitory concentration: 432 nM
Beside the measured number, compound 4's estimate is 3.9-fold (0.59 log units) below it, outside the stated range (above it).
By their numbers in this assay, from the lowest: compound 2; then compounds 4, 1 and 3 (each within the scatter of the next).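

In this assay closing the butyl chain into cyclobutyl changes little, with a 1.3-fold lower number from compound 3 to compound 4 (0.13 log units; within the scatter) and so no separation from the open-chain ethers, as a 1.0-fold lower number from compound 1 to compound 4 (0.00 log units; within the scatter) also shows. A ring on this saturated chain carbon is therefore not enough by itself, and ring size matters here, with an 8.2-fold higher number from compound 2 to compound 4 (0.91 log units; beyond the scatter) on going from cyclopentyl to cyclobutyl. Nothing shown here explains why these two rings differ. Still open, going by these compounds, is whether cyclohexyl keeps the lower number of compound 2, and whether a ring carrying an amine does the same.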